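Chlorines in place of methyls on the thiourea aryl ring

The source may report more compounds than this note shows. Statements on the series, on what has been measured and on what is new or still open speak of the compounds shown alone.

Compound 1 `CNC(=O)c1ccc(Oc2cccc(NC(=S)Nc3ccc(C)c(C)c3)c2)nc1` was tested in a functional assay on HepG2 cells (Homo sapiens) for antiproliferative activity, read by MTT assay; on this read-out lower numbers stand for stronger inhibition and higher numbers for weaker inhibition. In this assay compound 1 gives only a limit, > 100000 nM, not a number. This puts it at the limit of > 100000 nM in this assay, at which 1 of the 3 values shown sits. Among the measured compounds shown here, compound 2 `CNC(=O)c1ccc(Oc2cccc(NC(=S)Nc3ccc(F)cc3)c2)nc1` gives 42500 nM in this assay, and the single swap an at least 2.3-fold lower number from compound 1 to compound 2 (0.37 log units; beyond the scatter) shows that a halogen-bearing ring in place of the dimethyl ring brings the number down. Compound 3 `CNC(=O)c1ccc(Oc2cccc(NC(=S)Nc3cc(C(F)(F)F)cc(C(F)(F)F)c3)c2)nc1`, with two trifluoromethyl groups on that ring, gives 4550 nM in this assay. Compound 4 `CNC(=O)c1ccc(Oc2cccc(NC(=S)Nc3ccc(Cl)cc3Cl)c2)nc1` carries the change (2,4-dichlorophenyl in place of 3,4-dimethylphenyl on an amide-type nitrogen). Two halogens on that ring resemble compound 2 and compound 3 more than compound 1, so a lower number than compound 1 is expected, a step of an at least 6.6-fold lower number from compound 1 to compound 4 (0.82 log units; beyond the scatter). For compound 4 the estimate is 15000 nM, between 4000 nM and 60000 nM.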

Compound 4, half-maximal inhibitory concentration: 21600 nM
Compound 4: middle estimate off by 1.4-fold (0.16 log units), on the low side; the range from low to high includes it.
By their numbers in this assay, from the lowest: compound 3; then compounds 4 and 2 (each within the scatter of the next). At a limit, above all of these: compound 1.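

In this assay, 2,4-dichlorophenyl in place of 3,4-dimethylphenyl gives an at least 4.6-fold lower number from compound 1 to compound 4 (0.66 log units; beyond the scatter), so a second halogen-bearing ring also improves on the dimethyl ring, not only 4-fluorophenyl. Going on from 4-fluorophenyl to 2,4-dichlorophenyl gives a 2.0-fold lower number from compound 2 to compound 4 (0.29 log units; within the scatter), so these two rings cannot be told apart here. The true size of the first step stays unknown, since compound 1 is held at a limit and not a number: the limit of > 100000 nM in this assay, at which 1 of the 4 values shown sits.

Left open is how a ring carrying an amine or a carboxylic acid would behave, and whether a single chlorine would read like the two in 2,4-dichlorophenyl.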